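The source may hold more compounds than are shown below. What is called first, only, known or untested is meant among the compounds shown, and "the series" means these compounds.

Among the measured compounds shown here, compound 1 `O=C1C2=C(C(=O)c3ncccc31)C1(CS2)NC(=O)N(c2ccc(Cl)cc2)C1=O` gives 10 nM in a functional assay on MT4 cells (Homo sapiens) for antiproliferative activity, read by MTT assay, with a stated time of 96 h (on this read-out higher numbers stand for weaker inhibition and lower numbers for stronger inhibition), the higher of the two numbers so far, while compound 2 `O=C1C2=C(C(=O)c3ncccc31)C1(CS2)NC(=O)N(c2ccncc2)C1=O` gives 3 nM. For the measured compounds named here, the one measured step, a 3.3-fold lower number from compound 1 to compound 2 (0.52 log units; beyond the scatter), exchanges the whole aryl group on the amide-type nitrogen in the ring. Compound 3 `CC(C)(C)c1ccc(N2C(=O)NC3(CSC4=C3C(=O)c3ncccc3C4=O)C2=O)cc1` differs from compound 1 as follows: tert-butyl in place of chloro on an aromatic carbon. Going by the values given here, no measured step varies the group on the aromatic carbon of that six-membered ring of carbon only, so there is no direct precedent and no step beyond the scatter is expected, a 1.5-fold higher number from compound 1 to compound 3 (0.18 log units; within the scatter). Compound 3 is therefore estimated at 15 nM, within 5 nM to 50 nM.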

Compound 3, half-maximal inhibitory concentration: 200 nM
The estimate for compound 3 lay 13-fold (1.12 log units) below the measured number; measured number outside the range, above it.
By their numbers in this assay, from the lowest: compound 2; then compound 1; then compound 3.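

The aromatic carbon para to a large group does not tolerate every substituent: tert-butyl in place of chloro gives a 20-fold higher number from compound 1 to compound 3 (1.30 log units; beyond the scatter) in this assay, so this position is sensitive, which the aryl exchange alone could not show. Exchanging pyridin-4-yl for 4-(tert-butyl)phenyl on the amide-type nitrogen gives a 67-fold higher number from compound 2 to compound 3 (1.82 log units; beyond the scatter) in the same read-out, a far wider span than the earlier step. No evidence available here bears on why the loss is this large. Open, on these data alone, is whether methyl, methoxy or an amine on this carbon stays close to compound 1 or loses as much as tert-butyl does.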